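A few compounds are considered here, and "the series" means these few. Any claim that something is new, unique, unknown or untested is made for them only; others in the source may bear on it.

Measured compounds in a functional assay on HT-29 cells (Homo sapiens) for cytotoxicity, read by sulforhodamine B assay, with a stated time of 48 h; on this read-out higher numbers stand for weaker inhibition of growth and lower numbers for stronger inhibition of growth:

Compound 1 `COc1cc(C(=O)c2c[nH]c3cccc(OC)c23)c(N)c(OC)c1OC` — for compound 1 the result is > 100000 nM, which is a limit of the assay and not a number.
Compound 2 `COc1ccc2[nH]cc(C(=O)c3cc(OC)c(OC)c(OC)c3N)c2c1` — compound 2 gives 950 nM.
Compound 3 `COc1ccc2c(C(=O)c3cc(OC)c(OC)c(OC)c3N)c[nH]c2c1` — compound 3 gives 143 nM.

All three share a core in which a methoxy-bearing bicyclic ring is joined through a carbonyl to an amino-trimethoxyphenyl ring; they differ only in where the single methoxy sits on the bicyclic part. Compound 3 has the lowest number of the two that were measured as numbers; compound 2 sits higher by a gap that lies beyond the usual scatter. Compound 1 sits at the limit (the limit of > 100000 nM in this assay, at which 1 of the 3 values shown sits).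

The next compound, compound 4 `COc1cc2[nH]cc(C(=O)c3cc(OC)c(OC)c(OC)c3N)c2cc1OC`, keeps everything of compound 3 and adds one group: methoxy in place of hydrogen on an aromatic carbon, in words a methoxy in place of hydrogen on an aromatic carbon, sitting ortho to the methoxy that compound 3 already carries. Among the compounds with values here, no measured pair with this kind of change is available, so the size of the step rests on judgement alone. The spread from compound 2 to compound 3 shows that the position of a methoxy on this ring moves the number well beyond the scatter, so a second methoxy could shift it either way; a modest weakening seems the more likely outcome. The step from compound 3 to compound 4 is expected to be a 2.1-fold higher number from compound 3 to compound 4 (0.32 log units; beyond the scatter), and the estimate for compound 4 in this assay is 300 nM, within a range from 60 nM to 1500 nM.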

Compound 4, concentration for 50% growth inhibition: 24400 nM
Beside the measured number, compound 4's estimate is 81-fold (1.91 log units) below it; the whole stated range lies below it.
By their numbers in this assay, from the lowest: compound 3; then compound 2; then compound 4. At a limit, above all of these: compound 1.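

In this assay a methoxy in place of hydrogen on an aromatic carbon, ortho to a methoxy group, brings a 170-fold higher number from compound 3 to compound 4 (2.23 log units; beyond the scatter) and also a 26-fold higher number from compound 2 to compound 4 (1.41 log units; beyond the scatter) in the comparison with the other compound carrying one methoxy on this ring. The earlier compounds shown here showed only what happens when a single methoxy changes place: compound 2 gives 950 nM and compound 3 gives 143 nM on this ring, a much smaller gap than either new step. Compound 4 now shows that a methoxy at either of these two places goes with clear growth inhibition when it stands alone, whereas the same two groups together go with a far higher number, so the result for one methoxy here cannot be carried over to a compound that has both.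

From the compounds shown here alone, what a smaller or different group would do at this same place stays open, for instance a fluorine or a hydroxyl in place of the added methoxy. Nothing among the measurements shown explains why this single added group moves the number so far.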